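This account rests on a few compounds, and the source may have more. Where it says the series, first, only, none or still open, it means among the compounds named here.

Measured so far in an ADME assay on HEL cells (Homo sapiens) for cytotoxicity, with a stated time of 3 days; on this read-out higher numbers stand for lower toxicity in this test and lower numbers for higher toxicity in this test:
- compound 1 `CCC1(Cc2ccccc2)OS(=O)(=O)CC1=O`: > 100000 nM.
- compound 2 `CC(C)CC1(Cc2ccccc2)OS(=O)(=O)C=C1OCc1ccccc1`: >= 80000 nM.

For compound 1 the value > 100000 nM is a limit of the assay, not a number; it sits at the limit of > 100000 nM in this assay, at which 1 of the 2 values shown sits. For compound 2 the value >= 80000 nM is likewise only a limit, at the limit of >= 80000 nM in this assay, at which 1 of the 2 values shown sits. Among the compounds with values here, compound 2 thus stands at a limit, and the one further value shown is also a limit, so the two cannot be ordered against each other and no step between measured compounds can be read out.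

Compound 3 `CCCC1(Cc2ccccc2)OS(=O)(=O)C=C1OCc1ccccc1` differs from compound 2 by hydrogen in place of methyl on a saturated chain carbon bound to two saturated chain carbons. Within the data shown here, with no measured step to lean on, the step from compound 2 to compound 3 is expected to be none beyond the scatter, so a number no higher from compound 2 to compound 3 (the limit leaves the size open) is the expectation, and compound 3 is most likely to return a limit again. Compound 3 is accordingly estimated at 80000 nM, with a range from 30000 nM to 100000 nM.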

Compound 3, minimum cytotoxic concentration: >= 400000 nM
Compound 3: only a limit was reported (the forecaster's own chance of this, stated with the estimate: 75%); middle value at least 5.0-fold (0.69 log units) from the limit.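

Within the data shown here, compound 2 and compound 3 both stand only as limits in this assay, and no step from one to the other can be read. The compounds shown leave open whether hydrogen in place of methyl at this saturated chain carbon changes the read-out at all, and in which direction.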